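The compounds below may be only part of what the source reports. "The series", "measured", "known", "first", "only" and "open" are said of these compounds alone.

Compound 1, `CCCCCc1cc2c(=O)n(CC3CC3)cnc2s1`, in an ADME assay on A549 cells (Homo sapiens) for cytotoxicity, read by MTT assay, with a stated time of 11 days (on this read-out higher numbers stand for weaker inhibition of growth and lower numbers for stronger inhibition of growth), gives > 100 ug/mL, which is a limit of the assay rather than a number.
Compound 2, `CCCCCCc1cc2c(=O)n(CC3CC3)cnc2s1`, gives > 100 ug/mL, again a limit.
Compound 3, `CCCCCCCc1cc2c(=O)n(CC3CC3)cnc2s1`, gives > 100 ug/mL, also a limit.

Compound 2 stands where every measured compound stands, at the limit of > 100 ug/mL in this assay, at which 3 of the 3 values shown sit, so no number places it among the others. The step that the two limits leave unreadable from compound 1 to compound 2 is a lengthening of the alkyl chain, as is a step that the two limits leave unreadable from compound 1 to compound 3 and a step that the two limits leave unreadable from compound 2 to compound 3; because the limit of > 100 ug/mL in this assay, at which 3 of the 3 values shown sit, caps all three values, none of these steps has a readable size.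

Compound 4, `CCCCCCc1cc2c(=O)n(CCN=[N+]=[N-])cnc2s1`, differs from compound 2 by azidomethyl in place of cyclopropyl on a saturated chain carbon bound to an aromatic nitrogen. Going by the values given here, this change touches the group on the aromatic nitrogen, a part of the molecule that none of the measured steps alters, and even the chain-lengthening steps themselves give no readable size. Among the compounds with values here, the measured data therefore offer no step of known size to carry over to compound 4.

With three limits and no numbers, the most likely outcome for compound 4 is another limit. Compound 4 is expected to give 150 ug/mL, within a range from 50 ug/mL to 400 ug/mL. The estimated step that the limit leaves unreadable from compound 2 to compound 4 is meant as no change beyond the scatter, since nothing measured points in either direction.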

Compound 4, concentration for 50% growth inhibition: 16.2 ug/mL
Compound 4: the middle estimate sits 9.3-fold (0.97 log units) above what was measured, outside the stated range (below it).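

In this assay, going by these compounds alone, the group on the aromatic nitrogen proves able to move the read-out: changing cyclopropyl to azidomethyl at this place gives an at least 6.1-fold lower number from compound 2 to compound 4 (0.79 log units; beyond the scatter), the first step of readable size. On this read-out a lower number stands for stronger inhibition of growth, so this single change, with the rest of the molecule left as it was, makes compound 4 a stronger inhibitor of growth than compound 2. The printed size is only a minimum, and the chain-lengthening steps among compound 1, compound 2 and compound 3 cannot be read at all, because each of these compounds carries a limit of the assay rather than a number: the limit of > 100 ug/mL in this assay, at which 3 of the 4 values shown sit.

One change cannot say whether the effect comes from the azide itself or simply from replacing the cyclopropyl ring, and an amine or a plain propyl chain at the same place would help separate those two readings. From the compounds shown here alone, it also remains open whether the azidomethyl change would have a similar effect on the shorter and longer chains of compound 1 and compound 3.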